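A few compounds are considered here, and "the series" means these few. Any claim that something is new, unique, unknown or untested is made for them only; others in the source may bear on it.

Compound 1 `Cc1ccc(/C=N/c2ccc(OCc3ccccc3)cc2)c(O)c1` was tested in a functional assay, with a stated time of 30 min; on this read-out lower numbers stand for stronger inhibition and higher numbers for weaker inhibition. In this assay compound 1 gives only a limit, > 200000 nM. Compound 2 `Oc1ccc(/C=N/c2ccc(OCc3ccccc3)cc2)c(O)c1O` gives 43400 nM in this assay. Compound 1 thus stands at the limit of > 200000 nM in this assay, at which 1 of the 2 values shown sits, the weaker end of what is shown. Compound 3 `Oc1ccc(Br)cc1/C=N/c1ccc(OCc2ccccc2)cc1` differs from compound 1 by 5-bromo-2-hydroxyphenyl in place of 2-hydroxy-4-methylphenyl on a carbon with a double bond to nitrogen. Within the data shown here, no measured step links such a change to a result here; the step from compound 1 to compound 3 is expected to be modest, at most a slight gain, an at least 1.6-fold lower number from compound 1 to compound 3 (0.22 log units; that floor lies within the scatter). Compound 3 is estimated at 120000 nM, within a range from 30000 nM to 400000 nM, and may again return only a limit.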

Compound 3, half-maximal inhibitory concentration: > 200000 nM
Compound 3: a limit, no number (the forecaster's own chance of this, stated with the estimate: 55%); middle value at least 1.6-fold (0.22 log units) away from the limit.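

Among these compounds, compound 1 and compound 3 both return only a limit in this assay, so no step between them can be read. The compounds shown leave open whether 5-bromo-2-hydroxyphenyl in place of 2-hydroxy-4-methylphenyl changes inhibition at all.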